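Lengthening the chain on the shared core

The source may hold more compounds than are shown below. What is called first, only, known or untested is meant among the compounds shown, and "the series" means these compounds.

In a functional assay on HepG2 cells (Homo sapiens) for cytotoxicity (on this read-out lower numbers stand for stronger inhibition and higher numbers for weaker inhibition), compound 1 `CO[C@H]1C=C(COC(C)=O)C(=O)[C@H](O)[C@H]1O` is reported as > 50000 nM and that value is a limit of the assay. Compound 2 `CCCO[C@H]1C=C(COC(C)=O)C(=O)[C@H](O)[C@H]1O` gives 33600 nM as a measured number. Within the data shown here, compound 3 `CCCCCO[C@H]1C=C(COC(C)=O)C(=O)[C@H](O)[C@H]1O` gives 16100 nM and holds the lowest number so far. Among the measured compounds shown here, compound 4 `CCCCCCCO[C@H]1C=C(COC(C)=O)C(=O)[C@H](O)[C@H]1O` carries the chain further with ethyl in place of hydrogen on a saturated chain carbon, five bonds along the chain from an oxygen on a saturated carbon as its only change. For the measured compounds named here, two measured steps bear on this: a 2.1-fold lower number from compound 2 to compound 3 (0.32 log units; beyond the scatter) is the same kind of chain extension and modest in size, and an at least 3.1-fold lower number from compound 1 to compound 3 (0.49 log units; beyond the scatter) points the same way. Another modest fall is therefore expected in this assay for this longer chain. The estimated step is a 2.0-fold lower number from compound 3 to compound 4 (0.30 log units; within the scatter) in size. For compound 4 the expected value is 8000 nM with 3500 nM to 18000 nM as the estimated range.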

Compound 4, half-maximal inhibitory concentration: > 50000 nM
Compound 4: a limit, no number; the forecaster's own chance of this, stated with the estimate: 5%; middle value at least 6.2-fold (0.79 log units) from the limit.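

Compound 4 is reported only as a limit, > 50000 nM, and the step between it and compound 1 cannot be read. In this assay, lengthening the chain stops lowering the number at this position: an at least 3.1-fold higher number from compound 3 to compound 4 (0.49 log units; beyond the scatter) turns the earlier fall around, and an at least 1.4-fold higher number from compound 2 to compound 4 (0.17 log units; that floor lies within the scatter) leaves compound 4 behind compound 2 as well. The same kind of extension therefore does not give the same result at every chain length: the same change on two cores in this assay, an at least 1.4-fold lower number (0.17 log units; that floor lies within the scatter) from compound 1 to compound 2 and an at least 3.1-fold higher number (0.49 log units; beyond the scatter) from compound 3 to compound 4, at least 4.6-fold (0.66 log units) apart, beyond the scatter of two such steps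

Left open is how far beyond the limit compound 4 truly lies. Also open, going by these compounds, is whether a chain of the same length ending in an amine or a carboxylic acid would behave like compound 3 or like compound 4.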